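A few compounds are considered here, and "the series" means these few. Any claim that something is new, unique, unknown or untested is made for them only; others in the source may bear on it.

Working notes on the series.

Compound 1 `Cc1cc(S(N)(=O)=O)ccc1NC(=O)COc1ccc(F)cc1Oc1ccc2ccccc2c1` gives 68600 nM in an ADME assay on C8166 cells (Homo sapiens) for cytotoxicity, read by MTT assay; on this read-out lower numbers stand for higher toxicity in this test and higher numbers for lower toxicity in this test. Compound 2 `Cc1cc(S(N)(=O)=O)ccc1NC(=O)COc1ccc(F)cc1Oc1ccc2ccccc2c1Cl` gives 47100 nM in this assay. The two differ by hydrogen in place of chloro on an aromatic carbon, and the step recorded is a 1.5-fold higher number from compound 2 to compound 1 (0.16 log units; within the scatter). Compound 3 `Cc1cc(S(N)(=O)=O)ccc1NC(=O)COc1ccc(Cl)cc1Oc1c(C)cc2ccccc2c1Cl` gives 42600 nM in this assay; the difference between the core of compound 3 and the core of compound 2 is not broken down here. Compound 4 `Cc1cc(S(N)(=O)=O)ccc1NC(=O)COc1ccc(Cl)cc1Oc1cc2ccccc2cc1C` is not yet measured in this assay. It differs from compound 3 by hydrogen in place of chloro on an aromatic carbon, the same kind of change as from compound 2 to compound 1, though here the place is also meta to a methyl group. For compound 4 the step expected from compound 3 is a 1.3-fold higher number from compound 3 to compound 4 (0.11 log units; within the scatter), because the earlier step of a 1.5-fold higher number from compound 2 to compound 1 (0.16 log units; within the scatter) was small. The value expected for compound 4 in this assay is 55000 nM, between 30000 nM and 100000 nM.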

Compound 4, half-maximal cytotoxic concentration: 76700 nM
Beside the measured number, compound 4's estimate is 1.4-fold (0.14 log units) below it; low and high end bracket the measured number.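

In this assay, hydrogen in place of chloro on an aromatic carbon gives a 1.8-fold higher number from compound 3 to compound 4 (0.26 log units; within the scatter) on the core of compound 3. Set beside the same change on the core of compound 1, the two steps show no readable difference: the same change on two cores in this assay, a 1.5-fold higher number (0.16 log units; within the scatter) from compound 2 to compound 1 and a 1.8-fold higher number (0.26 log units; within the scatter) from compound 3 to compound 4, 1.2-fold (0.09 log units) apart, within the scatter of two such steps. This shows that the change carries across these two cores without a distinct outcome on either, but it does not establish a real effect of the change, and two cores give no rule for the wider series.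

The compounds shown leave open whether another group on this aromatic carbon, such as an amine, a carboxylic acid or a longer chain, would give a step beyond the scatter.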